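Sulfonamide benzamide series: cytotoxicity working notes

A few compounds are considered here, and "the series" means these few. Any claim that something is new, unique, unknown or untested is made for them only; others in the source may bear on it.

Measured in an ADME assay on HepG2 2.2.15 cells (Homo sapiens) for cytotoxicity, read by luminescence, with a stated time of 3 days (on this read-out higher numbers stand for lower toxicity in this test and lower numbers for higher toxicity in this test), so far:
compound 1 `O=C(Nc1ccc(F)c(Cl)c1)c1ccc(F)c(S(=O)(=O)N2C[C@H](O)CC[C@H](O)C2)c1` gives 25500 nM
compound 2 `O=C(Nc1ccc(F)c(Cl)c1)c1ccc(F)c(S(=O)(=O)N2CCCCCC(O)C2)c1` gives 11000 nM

Compound 1 stands highest of the two numbers; its nearest neighbour is compound 2, reached by a 2.3-fold lower number from compound 1 to compound 2 (0.37 log units; beyond the scatter). Compound 3 `CC1(O)CCCCN(S(=O)(=O)c2cc(C(=O)Nc3ccc(F)c(Cl)c3)ccc2F)C1` differs from compound 1 by 3-hydroxy-3-methylazepan-1-yl in place of 3,6-dihydroxyazepan-1-yl on a sulfonyl sulfur. Among the compounds with values here, the only step at this position on the sulfonyl sulfur is the one to compound 2, modest and beyond the scatter, with the number falling. On that basis a similar modest fall is expected for compound 3, a 1.8-fold lower number from compound 1 to compound 3 (0.26 log units; within the scatter). In this assay compound 3 is estimated at 14000 nM, within 6000 nM to 30000 nM.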

Compound 3, half-maximal cytotoxic concentration: 10000 nM
Estimate against measurement, compound 3: 1.4-fold (0.15 log units) above; low and high end bracket the measured number.
By their numbers in this assay, from the lowest: compounds 3 and 2 (each within the scatter of the next); then compound 1.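

Swapping 3,6-dihydroxyazepan-1-yl for 3-hydroxy-3-methylazepan-1-yl on the sulfonyl sulfur keeps the seven-membered ring and still gives a modest step in this assay, a 2.6-fold lower number from compound 1 to compound 3 (0.41 log units; beyond the scatter), so a number clearly under that of compound 1 does not require the eight-membered ring of compound 2. The two single-hydroxy groups are not told apart, with a 1.1-fold lower number from compound 2 to compound 3 (0.04 log units; within the scatter). Nothing measured bears on the reason for these steps.

Compound 3 leaves the lost hydroxy and the added methyl unseparated. From the compounds shown here alone, how an amine or a carboxylic acid on the seven-membered ring would read remains open.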